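Reversing the drawn configuration in a cytotoxic series

This account rests on a few compounds, and the source may have more. Where it says the series, first, only, none or still open, it means among the compounds named here.

In a functional assay on FL5.12 cells (Mus musculus) for cytotoxicity, read by flow cytometry, with a stated time of 48 h (on this read-out higher numbers stand for weaker inhibition and lower numbers for stronger inhibition), compound 3 (`CCCCCCCCCC/C=C/O[C@@H]1CN[C@@H](CO)C1`) gives 2600 nM and sits level, within the scatter, with compound 1 (`CCCCCCCCCC/C=C/c1ccc(CO[C@H]2CN[C@H](CO)C2)cc1`) at 2400 nM and its close value. Compound 2 (`CCCCCCCCCCCCO[C@@H]1CN[C@@H](CO)C1`) at 1200 nM stands lower than compound 3, a gap beyond the scatter. Compound 4 (`CCCCCCCCCC/C=C/O[C@H]1CN[C@H](CO)C1`) has the same atoms and bonds as compound 3 and differs only in configuration as drawn (the two compounds have the same atoms and bonds and differ only in configuration as drawn: 2 of 3 stereo elements differ; a stereocentre at a saturated ring carbon is drawn S in compound 3 and R in compound 4; a stereocentre at a saturated ring carbon is drawn R in compound 3 and S in compound 4). Among the measured compounds shown here, no measured pair here isolates such a change, so the expectation rests on compound 3 at 2600 nM alone. No step beyond the scatter is expected in this assay and the estimated 1.1-fold lower number from compound 3 to compound 4 (0.03 log units; within the scatter) has no firm direction. Compound 4 is expected at 2400 nM within an estimated range (1200 nM to 4800 nM).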

Compound 4, half-maximal inhibitory concentration: 3300 nM
Estimate against measurement, compound 4: 1.4-fold (0.14 log units) below; low and high end bracket the measured number.
By their numbers in this assay, from the lowest: compounds 2, 1, 3 and 4 (each within the scatter of the next, the first and the last beyond it).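

In this assay, reversing both ring stereocentres gives a 1.3-fold higher number from compound 3 to compound 4 (0.10 log units; within the scatter), so configuration at these two centres leaves the number level for this pair. No earlier comparison could show this, and the reading is a clean one, as it rests on a single kind of change: the fact that compounds 3 and 4 differ only in the configuration as drawn. The result covers this one pair only, not the reversed forms of compound 1 or compound 2. Still open, on these data alone, is whether configuration would count for more in compounds carrying a carboxylic acid or a primary amine on the shared core.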